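This account rests on a few compounds, and the source may have more. Where it says the series, first, only, none or still open, it means among the compounds named here.

Compound 1, `O=C(Nc1ccc(Oc2ccnc3[nH]ccc23)cc1)c1cc2cccnc2n(-c2ccccc2)c1=O`, is the starting point of this small set; in a functional assay on NCI-H460 cells (Homo sapiens) for antiproliferative activity, read by MTT assay, with a stated time of 72 h (a higher number here means a weaker inhibitor, a lower number a stronger inhibitor), compound 1 gives 380 nM. Compound 2, `O=C(Nc1ccc(Oc2ccnc3[nH]ccc23)c(F)c1)c1cc2cccnc2n(-c2ccccc2)c1=O`, differs from it in one place, (fluoro in place of hydrogen on an aromatic carbon), and in this assay compound 2 gives 180 nM, so that a 2.1-fold lower number from compound 1 to compound 2 (0.32 log units; beyond the scatter). Compound 3, `Cn1ccc2c(Oc3ccc(NC(=O)c4cc5cccnc5n(-c5ccccc5)c4=O)cc3F)ccnc21`, carries a methyl in place of hydrogen on an aromatic nitrogen relative to compound 2, and in this assay compound 3 gives 550 nM; the step is a 3.1-fold higher number from compound 2 to compound 3 (0.49 log units; beyond the scatter). How compound 3 differs from compound 1 is not broken down here.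

Compound 4, `Cn1ccc2c(Oc3ccc(NC(=O)c4cc5cccnc5n(-c5ccc(F)cc5)c4=O)cc3F)ccnc21`, has not been measured. It differs from compound 3 in one place, (fluoro in place of hydrogen on an aromatic carbon). This is the same kind of change as from compound 1 to compound 2, not the same: there the new fluoro sat ortho to a large group and meta to a large group, here it sits para to a large group, on a different ring. Given that a 2.1-fold lower number from compound 1 to compound 2 (0.32 log units; beyond the scatter), a similar step is expected, so that the estimate is a 1.4-fold lower number from compound 3 to compound 4 (0.14 log units; within the scatter) in this assay. Compound 4 is therefore expected to give about 400 nM, with a range from 150 nM to 1100 nM.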

Compound 4, half-maximal inhibitory concentration: 250 nM
The estimate for compound 4 lay 1.6-fold (0.20 log units) above the measured number, within the range that was stated.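

Replacing phenyl with 4-fluorophenyl gives a 2.2-fold lower number from compound 3 to compound 4 (0.34 log units; beyond the scatter) in this assay. Set beside the earlier fluoro step on the core of compound 1, this step agrees with it in size: the same change on two cores in this assay, a 2.1-fold lower number (0.32 log units; beyond the scatter) from compound 1 to compound 2 and a 2.2-fold lower number (0.34 log units; beyond the scatter) from compound 3 to compound 4, 1.0-fold (0.02 log units) apart, within the scatter of two such steps. This shows that, in these two pairs, fluoro in place of hydrogen on an aromatic carbon lowered the number by a similar amount on two cores, but the new fluoro sits on a different ring in each pair, so it does not show that one site carries its effect from core to core, and two pairs establish no general rule for the series.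

The compounds shown leave open whether the 4-fluorophenyl group would give a similar step on the core of compound 2, which carries the hydrogen on the aromatic nitrogen instead of the methyl. They also leave open how a chloro, a methoxy or an amine in place of the fluoro on that group would compare.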